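The compounds below may be only part of what the source reports. "The series", "measured", "known", "first", "only" and "open" are said of these compounds alone.

Of the compounds shown here, three have been measured in a functional assay on OVCAR-3 cells (Homo sapiens) for activation, with a stated time of 24 h; on this read-out lower numbers stand for an effect already at smaller amounts and higher numbers for an effect only at larger amounts of compound. Compound 1, with the structure `O=C(Nc1cccc(S(=O)(=O)C2CCCC2)c1)c1cccnc1N1CCCCC1`, gives 6350 nM. Compound 2, with the structure `O=C(Nc1cccc(S(=O)(=O)C2COC2)c1)c1cccnc1N1CCC2(CC1)CC2`, gives 14800 nM. Compound 3, with the structure `CC(C)(CO)Nc1ccc(C(=O)Nc2cccc(S(=O)(=O)NC3CCCC3)n2)c(N2CCC3(CC2)CC3)c1`, gives 48 nM. Among these three numbers, compound 1 stands second highest: the number of compound 2 lies above it, and the number of compound 3 lies far below it, and both of these gaps are beyond the usual scatter of this assay. Going by the values given here, no single-point step between any two of the measured compounds has been worked out, so nothing more can be read from these pairs than what their numbers show.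

Compound 4, with the structure `O=C(Nc1cccc(S(=O)(=O)C2CCCC2)c1)c1cccnc1N1CCC(F)(F)CC1`, has not yet been measured. It differs from compound 1 in one place: 4,4-difluoropiperidin-1-yl in place of piperidin-1-yl on an aromatic carbon. The measured compounds give no direct guide to what this change does, since none of them differ from each other in this way. The step from compound 1 to compound 4 is therefore expected to be small, with the estimated shift being a 1.2-fold lower number from compound 1 to compound 4 (0.06 log units; within the scatter), which would not exceed the scatter. On this basis compound 4 is expected to give about 5500 nM in this assay, within a range of 2000 nM to 16000 nM.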

Compound 4, half-maximal effective concentration: 4630 nM
The estimate for compound 4 lay 1.2-fold (0.07 log units) above the measured number; low and high end bracket the measured number.
By their numbers in this assay, from the lowest: compound 3; then compounds 4 and 1 (each within the scatter of the next); then compound 2.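

In this assay, placing 4,4-difluoropiperidin-1-yl instead of piperidin-1-yl on the aromatic carbon next to the ring nitrogen gives a 1.4-fold lower number from compound 1 to compound 4 (0.14 log units; within the scatter), a step too small to separate the two compounds. Going by these compounds alone, this is the first direct reading at this position, and it shows that the ring here can carry two fluorine atoms without a shift beyond the usual scatter. No separate measurement is at hand that could explain this result.

On these data alone, it remains open whether a different group at this position, such as morpholin-4-yl or dimethylamino, would move the number further. Also open, as far as these compounds go, is whether the same exchange would change so little on a different core, such as that of compound 3, which gives 48 nM.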